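Chloro to fluoro in a pair of strong inhibitors

The source may report more compounds than this note shows. Statements on the series, on what has been measured and on what is new or still open speak of the compounds shown alone.

Measured in a functional assay on MCF7 cells (Homo sapiens) for cytotoxicity, read by MTT assay, with a stated time of 48 h; a higher number here means a weaker inhibitor, a lower number a stronger inhibitor:
compound 1 `C/C(=N/NC(=S)Nc1ccc(F)cc1)c1ccccn1`: 1.2 nM
compound 2 `CC(=NNC(=S)Nc1ccc(Cl)cc1)c1ccccn1`: 8.5 nM

Compound 2 has the higher of the two numbers, which makes it the weaker inhibitor, and its gap to compound 1 lies beyond the usual scatter. Compound 3 `CC(=NNC(=S)Nc1ccc(F)cc1)c1ccccn1` comes from compound 2 through one change: fluoro in place of chloro on an aromatic carbon. For the measured compounds named here, no measured step isolates this swap. In this assay a fall beyond the scatter is still expected, because compound 1, which also carries fluoro, gives 1.2 nM. The estimated change is a 5.7-fold lower number from compound 2 to compound 3 (0.75 log units; beyond the scatter). For compound 3 the expected value is 1.5 nM, with an estimated range from 0.5 nM to 7 nM.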

Compound 3, half-maximal inhibitory concentration: 1.2 nM
Beside the measured number, compound 3's estimate is 1.3-fold (0.10 log units) above it; measured number inside the range.
By their numbers in this assay, from the lowest: compounds 1 and 3 (each within the scatter of the next); then compound 2.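

In this assay, fluoro in place of chloro on this aromatic carbon now has a size of its own, measured as a single change: a 7.1-fold lower number from compound 2 to compound 3 (0.85 log units; beyond the scatter). Until now, the swap could only be inferred from compound 1, not read from a measured step. A second step reads no change at the digits printed from compound 1 to compound 3 (within the scatter), and what separates that pair is only how it is drawn: the fact that one of compounds 1 and 3 is drawn with a defined configuration and the other without, at the place where they differ.

Going by these compounds, how an amine, a methoxy group or a carboxylic acid would fare at this place remains open. The same holds for plain hydrogen there.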